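Aryl change on the shared core: compound 2 to compound 3

A few compounds are considered here, and "the series" means these few. Any claim that something is new, unique, unknown or untested is made for them only; others in the source may bear on it.

- compound 1 `COc1cc(-n2cnc3ccc(-c4cccc(N)c4)cc32)cc(OC)c1OC`: 21 nM
- compound 2 `COc1cc(-n2cnc3ccc(-c4ccc(C)cc4)cc32)cc(OC)c1OC`: 200 nM

Among the compounds with values here, in a functional assay on SGC-7901 cells (Homo sapiens) for antiproliferative activity, read by MTT assay, with a stated time of 72 h (on this read-out higher numbers stand for weaker inhibition and lower numbers for stronger inhibition), compound 2 gives 200 nM, the higher of the two numbers so far. The next change leads to compound 3 `COc1cc(-n2cnc3ccc(-c4ccc(Cl)cc4Cl)cc32)cc(OC)c1OC`: 2,4-dichlorophenyl in place of 4-methylphenyl on an aromatic carbon, with 2,4-dichlorophenyl in place of 4-methylphenyl on an aromatic carbon.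

Within the data shown here, only one measured step bears on this change: a 9.5-fold higher number from compound 1 to compound 2 (0.98 log units; beyond the scatter). It involves the same aromatic carbon and shows that a change of group there can move the number beyond the scatter. Neither measured compound carries chlorine, so the data give no firm direction. A smaller step is expected, leaning slightly towards a higher number: like compound 2, compound 3 lacks the 3-aminophenyl group of compound 1, which gives 21 nM.

The expected step is a 1.3-fold higher number from compound 2 to compound 3 (0.10 log units; within the scatter). The estimated value for compound 3 is 250 nM, with an expected range of 60 nM to 1000 nM.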

Compound 3, half-maximal inhibitory concentration: > 10000 nM
Compound 3 was reported as a limit; the forecaster's own chance of this, stated with the estimate: 3%; at least 40-fold (1.60 log units) between middle value and limit.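

Compound 3 is reported in this assay only as a limit: the limit of > 10000 nM in this assay, at which 1 of the 3 values shown sits.

Replacing 4-methylphenyl with 2,4-dichlorophenyl gives an at least 50-fold higher number from compound 2 to compound 3 (1.69 log units; beyond the scatter), and replacing 3-aminophenyl with 2,4-dichlorophenyl gives an at least 470-fold higher number from compound 1 to compound 3 (2.67 log units; beyond the scatter). Both steps exceed the earlier 9.5-fold higher number from compound 1 to compound 2 (0.98 log units; beyond the scatter), which shows that a change on this aromatic carbon can do far more than move the number modestly, and that two aryl groups without the amine can differ widely.

The compounds shown do not separate the two chlorines of 2,4-dichlorophenyl, and it stays open whether either one alone goes with the large step. Also open, on these data alone, is how a hydroxyl or a carboxylic acid in place of the amine of 3-aminophenyl would read in this assay.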